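The compounds below may be only part of what the source reports. "The series", "measured", "known", "first", "only" and "open" are said of these compounds alone.

Of the compounds shown here, three built on one shared core have been tested in a functional assay on KM12 cells (Homo sapiens) for inhibition, read by sulforhodamine B assay, with a stated time of 48 h, tested at 0.01 uM; on this read-out higher numbers stand for a weaker effect at the one concentration tested and lower numbers for a stronger effect. Compound 1 `COc1cc(Cl)cc(-c2nn(-c3cccc(NC(=O)Nc4ccc(Cl)c(C(F)(F)F)c4)c3)cc2-c2ccncc2)c1` gives 95%, compound 2 `COc1cc(Cl)cc(-c2nn(-c3cccc(NC(=O)Nc4ccc(Cl)c(Cl)c4)c3)cc2-c2ccncc2)c1` gives 96%, and compound 3 `COc1cc(Cl)cc(-c2nn(-c3cccc(NC(=O)Nc4cccc(C(F)(F)F)c4)c3)cc2-c2ccncc2)c1` gives 97%. Among these numbers compound 3 sits at the top, but the steps of a number 1 percentage points higher from compound 1 to compound 2 (within the scatter), a number 2 percentage points higher from compound 1 to compound 3 (within the scatter) and a number 1 percentage points higher from compound 2 to compound 3 (within the scatter) all lie within the scatter, so the three cannot really be told apart. Compound 4 `COc1cc(Cl)cc(-c2nn(-c3cccc(NC(=O)c4cccc(C(F)(F)F)c4)c3)cc2-c2ccncc2)c1` differs from compound 3 by 3-(trifluoromethyl)phenyl in place of (3-(trifluoromethyl)phenyl)amino on a carbonyl carbon. Among the compounds with values here, none of the measured steps involves a change of this kind; each of them only exchanges one substituent for another, and each was small. With nothing pointing either way, no shift beyond the scatter is expected. The estimate for compound 4 is therefore 96%, within a range from 85% to 104%. That expectation means a step of a number 1 percentage points lower from compound 3 to compound 4 (within the scatter).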

Compound 4, a percentage reported as activity, at one concentration (the size of the read-out at that concentration, not a potency): 110%
Estimate against measurement, compound 4: 14 percentage points below; the measured number lies above the stated range.
By their numbers in this assay, from the lowest: compounds 1, 2 and 3 (each within the scatter of the next); then compound 4.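

In this assay the exchanges among compounds 1, 2 and 3 stayed within the scatter, but replacing the amino group on the carbonyl carbon weakens the effect, with a number 13 percentage points higher from compound 3 to compound 4 (beyond the scatter) and a number 14 percentage points higher from compound 2 to compound 4 (beyond the scatter) and also a number 15 percentage points higher from compound 1 to compound 4 (beyond the scatter) in the same direction. This position therefore responds to a change in the link itself, which removes one nitrogen and one hydrogen-bond donor. Nothing available explains the shift. As far as these compounds go, whether the nitrogen specifically matters remains open: a methylene group or an ether oxygen in its place on the carbonyl carbon would help separate its role from that of the link's length.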